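Series notes: the step from compound 2 to compound 4

The source may hold more compounds than are shown below. What is called first, only, known or untested is meant among the compounds shown, and "the series" means these compounds.

Three members of the series have been measured in an assay on isolated protein for inhibition of Amine oxidase [flavin-containing] A (Homo sapiens), read by spectrophotometry; on this read-out higher numbers stand for weaker inhibition and lower numbers for stronger inhibition. Compound 1 `COc1ccc(/C=N/Nc2nc3ccccc3nc2Cc2ccccc2)cc1OC` gives 56 nM, compound 3 `COc1ccc(/C=N/Nc2nc3ccccc3nc2Cc2ccccc2)cc1` gives 63 nM, and compound 2 `C(=N/Nc1nc2ccccc2nc1Cc1ccccc1)\c1ccccc1` gives 81 nM. Compound 2 carries the highest of the three numbers, but its nearest neighbour on this read-out is compound 3 and the gap is within the scatter; the same holds for compound 1, so no order among the three can be claimed.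

Compound 4 `C/C(=N\Nc1nc2ccccc2nc1Cc1ccccc1)c1ccccc1` is not yet measured. Relative to compound 2 the change is a group of 9 heavy atoms (8 carbon, 1 nitrogen; one six-membered aromatic ring of carbon only) in place of a group of 8 heavy atoms (7 carbon, 1 nitrogen; one six-membered aromatic ring of carbon only), on a nitrogen on an aromatic ring. Within the data shown here, none of the measured steps touches this place: a 1.4-fold higher number from compound 1 to compound 2 (0.16 log units; within the scatter), a 1.1-fold higher number from compound 1 to compound 3 (0.05 log units; within the scatter) and a 1.3-fold lower number from compound 2 to compound 3 (0.11 log units; within the scatter) all concern the aromatic ring and all lie within the scatter. Among the measured compounds shown here, there is therefore no direct precedent for the step to compound 4, and no step beyond the scatter in this assay is expected in either direction. The estimate for compound 4 is 90 nM, with a range of 40 nM to 200 nM, which means an expected step of a 1.1-fold higher number from compound 2 to compound 4 (0.05 log units; within the scatter).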

Compound 4, half-maximal inhibitory concentration: 79 nM
Compound 4: middle estimate off by 1.1-fold (0.06 log units), on the high side, within the range that was stated.
By their numbers in this assay, from the lowest: compounds 1, 3, 4 and 2 (each within the scatter of the next).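

In this assay the group of 9 heavy atoms in place of the group of 8 heavy atoms, on a nitrogen on an aromatic ring, gives a 1.0-fold lower number from compound 2 to compound 4 (0.01 log units; within the scatter) and so stays within the scatter. Among these compounds, the earlier steps all concerned the aromatic ring, so this is the first reading at this place: one added carbon in the group does not separate compound 4 from compound 2 on this read-out. That conclusion rests on this single pair, and no measurement is at hand that bears on why the number holds.

Going by these compounds, whether a longer chain such as propyl or a group carrying an amine at this place would also stay within the scatter remains open. Also open, on these data alone, is whether the same change gives a similar step on the methoxy-bearing compound 1 and compound 3.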